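Amide chain length in a dimethoxy-indane acetamide series

A few compounds are considered here, and "the series" means these few. Any claim that something is new, unique, unknown or untested is made for them only; others in the source may bear on it.

Compound 1 `CNC(=O)CC1CCc2cc(OC)c(OC)cc21`, compound 2 `CCNC(=O)CC1CCc2cc(OC)c(OC)cc21` and compound 3 `CCCCCNC(=O)CC1CCc2cc(OC)c(OC)cc21` share one core and differ only at the amide nitrogen. In a functional assay on the whole organism (strain Wistar) for inhibition, with Rattus norvegicus as the target, read by paw edema, with stated times of 60 min and 1 h, at a dose of 100 mg/kg by the oral route (on this read-out higher numbers stand for more inhibition at the one dose given (going by the name of the read-out) and lower numbers for less inhibition), compound 1 gives 15.6%, compound 2 gives 15.6% and compound 3 gives 34.4%. The change methyl in place of hydrogen on a saturated chain carbon bound to an amide-type nitrogen produced no change at the digits printed from compound 1 to compound 2 (within the scatter). Compound 3 differs from compound 1 by butyl in place of hydrogen on a saturated chain carbon bound to an amide-type nitrogen, and this gave a number 18.8 percentage points higher from compound 1 to compound 3 (beyond the scatter). Compound 4 `CCCCCCNC(=O)CC1CCc2cc(OC)c(OC)cc21` is not yet measured; it differs from compound 3 by methyl in place of hydrogen on a saturated chain carbon, five bonds along the chain from an amide-type nitrogen. This is the same kind of change as that from compound 1 to compound 2, but the place differs: there the carbon was bound to an amide-type nitrogen, here it lies five bonds along the chain from it. Because compound 3 stands at 34.4% after lengthening the chain, a small further gain is expected, a number 3.6 percentage points higher from compound 3 to compound 4 (within the scatter), though the flat step between compound 1 and compound 2 counsels caution. Compound 4 is estimated at 38%, expected between 22% and 54%.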

Compound 4, a percentage reported as inhibition, in the whole organism at one dose (the size of the read-out at that dose, not a potency): 47.6%
For compound 4 the middle estimate is 9.6 percentage points below the measured one, and the stated range covers the measured number.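

In this assay lengthening the amide chain beyond that of compound 2 keeps raising the number, with a number 13.2 percentage points higher from compound 3 to compound 4 (beyond the scatter), a number 32 percentage points higher from compound 2 to compound 4 (beyond the scatter) and a number 32 percentage points higher from compound 1 to compound 4 (beyond the scatter). The methyl change gives steps that cannot be told apart, though it sits at a different place on the chain in each case, and this shows no difference on carrying it over rather than a proven constant effect: the same change on two cores in this assay, no change at the digits printed (within the scatter) from compound 1 to compound 2 and a number 13.2 percentage points higher (beyond the scatter) from compound 3 to compound 4, 13.2 percentage points apart, within the scatter of two such steps The longer extension also carries over in direction, but a single pair of steps does not fix its size on other cores: the same change on two cores in this assay, a number 18.8 percentage points higher (beyond the scatter) from compound 1 to compound 3 and a number 32 percentage points higher (beyond the scatter) from compound 2 to compound 4, 13.2 percentage points apart, within the scatter of two such steps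

Going by these compounds, whether the rise continues with a longer chain such as octyl or decyl remains open. Also open, on these data alone, is how a branched chain, or a chain ending in an amine or a carboxylic acid, would read.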